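From a larger amine to dimethylamino on the shared core

A few compounds are considered here, and "the series" means these few. Any claim that something is new, unique, unknown or untested is made for them only; others in the source may bear on it.

In a functional assay on HCT-15 cells (Homo sapiens) for inhibition, read by MTT assay, with a stated time of 72 h (a lower number here means a stronger inhibitor, a higher number a weaker inhibitor), compound 1 (`COc1ccc(CCCNCc2c(OC)cc(Oc3ccc(Nc4ccccc4)cc3)cc2OC)cc1`) gives 2180 nM and compound 2 (`CNCc1c(OC)cc(Oc2cccc(Nc3ccccc3)c2)cc1OC`) gives 8930 nM while compound 3 (`COc1cc(Oc2cccc(Nc3ccccc3)c2)cc(OC)c1CNCc1ccc(C)cc1`) gives 5400 nM as its reading. Compound 3 therefore lies within the scatter of compound 2 and at a higher number, meaning a weaker inhibitor, than compound 1.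

Compound 4 (`COc1cc(Oc2cccc(Nc3ccccc3)c2)cc(OC)c1CN(C)C`) has not yet been measured. Its difference from compound 3 (dimethylamino in place of (4-methylbenzyl)amino on a saturated chain carbon bound to an aromatic carbon) is dimethylamino in place of (4-methylbenzyl)amino on a saturated chain carbon bound to an aromatic carbon.

Within the data shown here, one measured step bears on this (a 1.7-fold lower number from compound 2 to compound 3 (0.22 log units; within the scatter)). There, 4-methylphenyl stands in place of hydrogen on a saturated chain carbon bound to an amine nitrogen, and the two numbers stay within the scatter. Among the measured compounds shown here, compound 4 also lacks that ring, so compound 2 at 8930 nM is its nearest guide, although no measured compound carries dimethylamino.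

In this assay no step beyond the scatter is therefore expected, and any drift would be towards a higher number. Compound 4 is estimated at 8500 nM within an expected range of 3500 nM to 20000 nM for its measurement. That estimate means an expected step (a 1.6-fold higher number from compound 3 to compound 4 (0.20 log units; within the scatter)).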

Compound 4, half-maximal inhibitory concentration: 15600 nM
Compound 4: the middle estimate sits 1.8-fold (0.26 log units) below what was measured, within the range that was stated.
By their numbers in this assay, from the lowest: compound 1; then compounds 3, 2 and 4 (each within the scatter of the next, the first and the last beyond it).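

In this assay, dimethylamino in place of (4-methylbenzyl)amino on a saturated chain carbon bound to an aromatic carbon gives a 2.9-fold higher number from compound 3 to compound 4 (0.46 log units; beyond the scatter), the only step at this position shown here that passes beyond the scatter, and a modest one. Methyl in place of hydrogen on the amine nitrogen gives a 1.7-fold higher number from compound 2 to compound 4 (0.24 log units; within the scatter), which lies within the scatter, as does a 1.7-fold lower number from compound 2 to compound 3 (0.22 log units; within the scatter), so the amine of compound 2 cannot be told apart from either neighbouring amine, and only the pair at the two ends, compound 3 and compound 4, stands apart. No measurement shown here gives a reason for the step beyond the scatter.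

The compounds shown leave open whether the aromatic ring of the (4-methylbenzyl)amino group matters, or whether a plain benzylamino group, a cyclohexylmethylamino group or a longer chain on the amine would read the same. Compound 1 differs from the others in more than one place, so its amine, with its longer chain, cannot yet be judged on this core, and a matched compound carrying that amine would be needed to do so.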